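The source may report more compounds than this note shows. Statements on the series, on what has been measured and on what is new or still open speak of the compounds shown alone.

Compound 1 `CN(C)c1nc(N)c2ncn([C@@H]3C[C@@H](O)[C@H](CO)O3)c2n1` — in a functional assay on K562 cells (Homo sapiens) (a lower number here means a stronger inhibitor, a higher number a weaker inhibitor), compound 1 gives > 300 uM, which is a limit of the assay.
Compound 2 `CNc1nc(SC)nc2c1ncn2[C@@H]1C[C@@H](O)[C@H](CO)O1` — in this assay compound 2 gives > 300 uM, again a limit.
Compound 3 `CSc1nc(N(C)C)c2ncn([C@@H]3C[C@@H](O)[C@H](CO)O3)c2n1` — in this assay compound 3 gives > 300 uM, also a limit.

Compound 3 therefore stands nowhere on a numerical scale: its value is a limit, as are the two other values shown, and the step from compound 2 to compound 3, a step that the two limits leave unreadable from compound 2 to compound 3, cannot be read. The whole set sits at one place, (the limit of > 300 uM in this assay, at which 3 of the 3 values shown sit).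

The step to compound 4 `CSc1nc(N)c2ncn([C@@H]3C[C@@H](O)[C@H](CO)O3)c2n1` is amino in place of dimethylamino on an aromatic carbon. Within the data shown here, no measured step bears on it, since every measured compound returned a limit. Compound 1 carries an amino group at the same place as compound 4 and gives a limit, which is all its value shows. Compound 4 is therefore expected to give a limit as well, with a step that the limit leaves unreadable from compound 3 to compound 4 that remains unreadable. The estimate for compound 4 in this assay is 500 uM, ranging from 150 uM to 2000 uM.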

Compound 4, concentration for 50% inhibition: > 300 uM
Compound 4 was reported as a limit; the forecaster's own chance of this, stated with the estimate: 85%; the middle value does not contradict the limit.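

In this assay compound 4 gives > 300 uM as a limit. Its steps from compound 1, compound 2 and compound 3 therefore cannot be read. The compounds shown leave open which change to the shared core, if any, would bring a numerical value.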